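Replacing a Difluorophenyl Ring: Expected Tolerance in Vero Cells

The compounds below may be only part of what the source reports. "The series", "measured", "known", "first", "only" and "open" are said of these compounds alone.

Three measured compounds share one core and differ only in the aromatic ring attached to a carbonyl carbon. Compound 1 `COC(=O)c1cc(-c2cccc(NC(=O)c3ccc(/C=C/C(=O)c4cccnc4)cc3)c2)on1` was tested in an ADME assay on Vero cells (Chlorocebus sabaeus) for cytotoxicity, read by MTT assay, with a stated time of 72 h (a lower number here means that less compound is tolerated, a higher number that more compound is tolerated), but compound 1 gives only "not determined" (no result reported). In this assay compound 2 `COC(=O)c1cc(-c2cccc(NC(=O)c3ccc(/C=C/C(=O)c4ccc(C)c(F)c4)cc3)c2)on1` gives > 50 ug/mL, which is a limit of the assay and not a number. In this assay compound 3 `COC(=O)c1cc(-c2cccc(NC(=O)c3ccc(/C=C/C(=O)c4cc(F)ccc4F)cc3)c2)on1` gives > 40 ug/mL, again a limit rather than a number. The step that the two limits leave unreadable from compound 2 to compound 3 therefore cannot be sized, since both ends rest on limits the limit of > 40 ug/mL in this assay, at which 1 of the 3 values shown sits (the limit of > 50 ug/mL in this assay, at which 1 of the 3 values shown sits). Compound 3 thus stands at a limit, as does compound 2, while compound 1 has no number at all.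

Compound 4 `COC(=O)c1cc(-c2cccc(NC(=O)c3ccc(/C=C/C(=O)c4cccc(OC)c4)cc3)c2)on1` differs from compound 3 by 3-methoxyphenyl in place of 2,5-difluorophenyl on a carbonyl carbon. Within the data shown here, no measured step reads a change of this kind; the one step on the same carbonyl carbon was unreadable. With every tested analogue tolerated up to its limit, no movement beyond the scatter is expected, so the step that the limit leaves unreadable from compound 3 to compound 4 is estimated to be small. Compound 4 is expected to give 60 ug/mL, in the range 30 ug/mL to 120 ug/mL.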

Compound 4, half-maximal cytotoxic concentration: > 100 ug/mL
Compound 4 ended at the assay's limit (the forecaster's own chance of this, stated with the estimate: 75%); middle value at least 1.6-fold (0.22 log units) away from the limit.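

Compound 4, like compound 2 and compound 3, rests on a limit in this assay, so the steps linking these three compounds cannot be read. The compounds shown leave open the actual tolerated concentration of each one, and whether changing the ring on the carbonyl carbon shifts it at all.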